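The source may report more compounds than this note shows. Statements on the series, on what has been measured and on what is new or still open speak of the compounds shown alone.

Working notes on the series. In an ADME assay on the whole organism (Rattus norvegicus) for pharmacokinetics, at a dose of 1 mg/kg by the intravenous route (on this read-out lower numbers stand for narrower distribution and higher numbers for wider distribution into tissues), compound 1 (`O=C(c1cnco1)N1CCC(C(=O)N2N=CC[C@H]2c2ccccc2)CC1`) gives 2.1 L/kg and compound 3 (`O=C(c1c[nH]nn1)N1CCC(C(=O)N2N=CCC2c2ccccc2)CC1`) gives 1.3 L/kg. Compound 2 (`N#Cc1cnc(N2CCC(C(=O)N3N=CC[C@H]3c3cc(F)cc(F)c3)CC2)cn1`) gives 6.1 L/kg, the highest of the three numbers, and its gaps to compound 1 and compound 3 both lie beyond the scatter.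

Compound 4 (`N#Cc1cc(N2CCC(C(=O)N3N=CC[C@H]3c3cc(F)cc(F)c3)CC2)ncn1`) has not yet been measured. It differs from compound 2 in one place: a group of 8 heavy atoms (5 carbon, 3 nitrogen; one six-membered aromatic ring with 2 hetero atoms) in place of a group of 8 heavy atoms (5 carbon, 3 nitrogen; one six-membered aromatic ring with 2 hetero atoms), on an amine nitrogen in a ring. The 5-cyanopyrazin-2-yl group leaves and a group with no common name enters, on an amine nitrogen in a ring. The two compounds have the same atoms, joined differently.

Among the measured compounds shown here, no measured pair shows a change of this kind, so the expectation rests on the structural change alone. No step beyond the scatter is expected in this assay, with a slight lean downward since compound 2 is the top of the series at 6.1 L/kg. The expected move is a 1.2-fold lower number from compound 2 to compound 4 (0.09 log units; within the scatter), within the scatter. For compound 4 the estimate is 5 L/kg, with an expected range of 2.5 L/kg to 10 L/kg.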

Compound 4, volume of distribution at steady state: 4.6 L/kg
The estimate for compound 4 lay 1.1-fold (0.04 log units) above the measured number; the range from low to high includes it.
By their numbers in this assay, from the lowest: compounds 3 and 1 (each within the scatter of the next); then compounds 4 and 2 (each within the scatter of the next).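

In this assay, the step on the amine nitrogen in the ring, where the 5-cyanopyrazin-2-yl group gives way to a ring with the same atoms joined differently, is a 1.3-fold lower number from compound 2 to compound 4 (0.12 log units; within the scatter). Among the compounds shown here, this is the first one-place comparison, and it shows that this rearrangement of the ring leaves the read-out within the scatter, with both compounds still well clear of the values of the compounds with other groups at this place. Nothing measured here offers an explanation for this result.

The compounds shown leave open how much of the read-out depends on the nitrile, since a carboxylic acid or an amine in its place would test a different group rather than a different arrangement. They also leave open the separate contribution of the two fluorines on the phenyl ring, as compound 1 and compound 3 differ from compound 2 in more than one place.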